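Trimming the methoxy pattern on the amide-bound aryl

This account rests on a few compounds, and the source may have more. Where it says the series, first, only, none or still open, it means among the compounds named here.

The series holds one core and varies the aryl group on a saturated chain carbon bound to an amide-type nitrogen, scored in a functional assay on PC-3 cells (Homo sapiens) for antiproliferative activity, read by MTT assay, with a stated time of 48 h; on this read-out higher numbers stand for weaker inhibition and lower numbers for stronger inhibition. Compound 1 `COc1cc(N(Cc2ccccc2)C(=O)CSc2nc3ccccc3s2)cc(OC)c1OC` carries a plain phenyl there, and in this assay compound 1 gives 54100 nM. Compound 2 `COc1ccc(CN(C(=O)CSc2nc3ccccc3s2)c2cc(OC)c(OC)c(OC)c2)cc1N` carries 3-amino-4-methoxyphenyl and in this assay compound 2 gives 7510 nM, which is a 7.2-fold lower number from compound 1 to compound 2 (0.86 log units; beyond the scatter). Compound 3 `COc1cc(CN(C(=O)CSc2nc3ccccc3s2)c2cc(OC)c(OC)c(OC)c2)cc(OC)c1OC` carries 3,4,5-trimethoxyphenyl. For compound 3 this assay returns only a limit, > 80000 nM, not a number. This is the limit of > 80000 nM in this assay, at which 1 of the 3 values shown sits. The steps into compound 3 are an at least 1.4-fold higher number from compound 1 to compound 3 (0.16 log units; that floor lies within the scatter) and an at least 10-fold higher number from compound 2 to compound 3 (1.02 log units; beyond the scatter), so compound 3 stands no better than compound 1 and clearly behind compound 2.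

Compound 4 `COc1ccc(CN(C(=O)CSc2nc3ccccc3s2)c2cc(OC)c(OC)c(OC)c2)cc1` is the next point: 4-methoxyphenyl in place of 3,4,5-trimethoxyphenyl on a saturated chain carbon bound to an amide-type nitrogen. Both steps into compound 3 bear on it, since compound 4 keeps one methoxy group and so sits structurally between the phenyl of compound 1 and the 3-amino-4-methoxyphenyl of compound 2, without the amine of compound 2. The expectation is therefore a return toward the region of compound 1 and compound 2, as an at least 2.0-fold lower number from compound 3 to compound 4 (0.30 log units; that floor lies within the scatter). Compound 4 is expected at 40000 nM, with a range of 10000 nM to 100000 nM.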

Compound 4, half-maximal inhibitory concentration: 8460 nM
For compound 4 the middle estimate is 4.7-fold (0.67 log units) above the measured one, and the stated range ends above it.
By their numbers in this assay, from the lowest: compounds 2 and 4 (each within the scatter of the next); then compound 1. At a limit, above all of these: compound 3.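

In this assay, 4-methoxyphenyl in place of 3,4,5-trimethoxyphenyl on a saturated chain carbon bound to an amide-type nitrogen restores measurable activity, with an at least 9.4-fold lower number from compound 3 to compound 4 (0.97 log units; beyond the scatter), and the size of that step is only a floor, as compound 3 is held at a limit of the assay and not at a number: the limit of > 80000 nM in this assay, at which 1 of the 4 values shown sits. The amino group of compound 2 proves dispensable in this comparison, as hydrogen in its place gives a 1.1-fold higher number from compound 2 to compound 4 (0.05 log units; within the scatter), which leaves the two compounds without an order. The gain over the plain phenyl goes with a single methoxy group, at a 6.4-fold lower number from compound 1 to compound 4 (0.81 log units; beyond the scatter), so the earlier gain of compound 2 need not be tied to its amine, while compound 3 goes against any reading that more methoxy groups give lower numbers.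

As far as these compounds go, it remains open whether the gain is specific to methoxy or would also appear with ethoxy, hydroxyl or a chlorine atom on the aromatic ring. A dimethoxyphenyl group would show whether the loss seen with compound 3 already sets in with one further methoxy group.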